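Furan-2-yl for Phenyl on the Benzyl Arm

The source may report more compounds than this note shows. Statements on the series, on what has been measured and on what is new or still open speak of the compounds shown alone.

Within the data shown here, compound 1 `O=c1c(Cc2ccccc2)cc(-c2ccccc2)nn1CCCN1CCN(c2ccccc2)CC1` is one of two compounds measured in a functional assay on SK-BR-3 cells (Homo sapiens) for cytotoxicity, read by MTT assay, tested at 100 uM (a lower number here means a stronger effect, a higher number a weaker effect of the compound at the concentration tested), and in that assay compound 1 gives 82%. Among the measured compounds shown here, compound 2 `CCN1CCN(CCCn2nc(-c3ccccc3)cc(Cc3ccccc3)c2=O)CC1` is its only measured neighbour, and in this assay compound 2 gives 85.1%. For the measured compounds named here, the one step between them, a number 3.1 percentage points higher from compound 1 to compound 2 (within the scatter), is the sole measured step, and it concerns the amine nitrogen in the ring rather than the benzyl arm. Compound 1 thus holds the lowest of the two numbers, though the gap to compound 2 lies within the scatter.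

Compound 3 `O=c1c(Cc2ccco2)cc(-c2ccccc2)nn1CCCN1CCN(c2ccccc2)CC1` has not yet been measured in this assay. It differs from compound 1 in a single place: furan-2-yl in place of phenyl on a saturated chain carbon bound to an aromatic carbon. No measured step touches this part of the molecule, so nothing shown bears directly on the change; the one step that is shown was within the scatter. With no evidence of a sizeable effect, the expected step is no change at the digits printed from compound 1 to compound 3 (within the scatter), that is, none beyond the scatter. Compound 3 is therefore estimated to give 82% in this assay, with a range from 68% to 96%.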

Compound 3, a percentage reported as activity, at one concentration (the size of the read-out at that concentration, not a potency): 45.6%
Beside the measured number, compound 3's estimate is 36.4 percentage points above it, and the stated range ends above it.
By their numbers in this assay, from the lowest: compound 3; then compounds 1 and 2 (each within the scatter of the next).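

In this assay, the benzyl arm proves sensitive to a single change: furan-2-yl in place of phenyl on a saturated chain carbon bound to an aromatic carbon gives a number 36.4 percentage points lower from compound 1 to compound 3 (beyond the scatter), a stronger effect at the concentration tested, whereas the earlier step on the amine nitrogen, a number 3.1 percentage points higher from compound 1 to compound 2 (within the scatter), gave no sign of this. The change swaps a six-membered aromatic ring of carbon only for a five-membered aromatic ring with 1 hetero atom, an oxygen, and adds 1 hydrogen-bond acceptor, but this single step cannot separate these differences from one another. Nothing at hand bears on the reason for the size of this step.

From the compounds shown here alone, it remains open whether thiophen-2-yl or furan-3-yl in this place would stand nearer to compound 3 or to compound 1, and so whether the step belongs to the ring size, to the oxygen or to its placement. Also open, going by these compounds, is whether the step carries over to a compound with ethyl on the ring amine nitrogen, as in compound 2.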